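The compounds below may be only part of what the source reports. "The series", "measured", "known", "first", "only" and "open" are said of these compounds alone.

Measured so far:
compound 1, `Cn1c(I)nc2ccccc21`, gives 17500 nM in a functional assay on HCT-116 cells (Homo sapiens) for cytotoxicity, with a stated time of 3 days; a lower number here means a stronger inhibitor, a higher number a weaker inhibitor
compound 2, `C#Cc1sc(-c2ccc(F)cc2)nc1C(=O)OCC`, gives > 40000 nM
compound 3, `C=Cc1nc2ccccc2[se]1`, gives > 40000 nM

Compound 2 sits at the limit of > 40000 nM in this assay, at which 2 of the 3 values shown sit; its value is a limit of the assay and not a number. Compound 4, `C=Cc1sc(-c2ccc(F)cc2)nc1C(=O)OCC`, differs from compound 2 by vinyl in place of ethynyl on an aromatic carbon. Going by the values given here, no two measured compounds differ in only one place, so no measured step tells the size of such a change in this assay. For compound 4 no step beyond the usual scatter is expected in this assay, and the expected change is a number no higher from compound 2 to compound 4 (the limit leaves the size open). The estimate for compound 4 is 40000 nM, in the range from 15000 nM to 100000 nM, and the estimate most likely comes back as a limit again.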

Compound 4, half-maximal inhibitory concentration: > 40000 nM
Compound 4 was reported as a limit (the forecaster's own chance of this, stated with the estimate: 75%); the middle value sits exactly at the limit.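

Compound 2 and compound 4 are both limits and not numbers, so no step can be read for vinyl in place of ethynyl: the limit of > 40000 nM in this assay, at which 3 of the 4 values shown sit. The compounds shown leave open how vinyl and ethynyl compare in this assay.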